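Can 3-iodophenyl rescue compound 3?

The source may hold more compounds than are shown below. What is called first, only, known or untested is meant among the compounds shown, and "the series" means these compounds.

In a functional assay on M21 cells (Homo sapiens) for antiproliferative activity, read by sulforhodamine B assay, with a stated time of 48 h (on this read-out higher numbers stand for weaker inhibition and lower numbers for stronger inhibition), compound 3 (`CCN1CCN(c2ccc(S(=O)(=O)Oc3ccccc3OC)cc2)C1=O`) reads > 100000 nM as a limit of the assay and not a number. In this assay compound 1 (`COc1ccccc1OS(=O)(=O)c1ccc(N2CCN(C)C2=O)cc1`) gives 21000 nM while compound 2 (`Cc1ccc(OS(=O)(=O)c2ccc(N3CCN(C)C3=O)cc2)c(C)c1`) gives 1800 nM as measured numbers.

Compound 4 (`CCN1CCN(c2ccc(S(=O)(=O)Oc3cccc(I)c3)cc2)C1=O`) has not yet been measured. It carries 3-iodophenyl in place of 2-methoxyphenyl on an oxygen whose other neighbour is the sulfonyl sulfur (3-iodophenyl in place of 2-methoxyphenyl on an oxygen).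

For the measured compounds named here, two measured steps bear on this change. The first, a 12-fold lower number from compound 1 to compound 2 (1.07 log units; beyond the scatter), came with 2,4-dimethylphenyl in place of 2-methoxyphenyl on an oxygen, so a swap at this same place has already moved the number by a large amount. The second, an at least 4.7-fold higher number from compound 1 to compound 3 (0.67 log units; beyond the scatter), came with methyl in place of hydrogen on a saturated chain carbon, and compound 4 keeps that extra methyl, so it starts from the weak side. Going by the values given here, no measured compound carries 3-iodophenyl, and compound 3 offers only a limit as a starting point. A lower number is still expected, and the estimated move is an at least 8.3-fold lower number from compound 3 to compound 4 (0.92 log units; beyond the scatter) for now. For compound 4 the expected value is 12000 nM with a range of 1500 nM to 90000 nM as the estimate.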

Compound 4, half-maximal inhibitory concentration: 2200 nM
Compound 4: the middle estimate sits 5.5-fold (0.74 log units) above what was measured; the range from low to high includes it.
By their numbers in this assay, from the lowest: compounds 2 and 4 (each within the scatter of the next); then compound 1. At a limit, above all of these: compound 3.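

In this assay, 3-iodophenyl in place of 2-methoxyphenyl on an oxygen whose other neighbour is the sulfonyl sulfur brings an at least 45-fold lower number from compound 3 to compound 4 (1.65 log units; beyond the scatter), so a change at this place can have a large effect even in a compound that keeps the extra methyl. For the compounds shown here, until now, the only swap seen at this oxygen, a 12-fold lower number from compound 1 to compound 2 (1.07 log units; beyond the scatter), was in compounds without that methyl, and the methyl itself had brought an at least 4.7-fold higher number from compound 1 to compound 3 (0.67 log units; beyond the scatter), which left open whether that loss could be recovered. The new step gives only a minimum size, since compound 3 stands at a limit of the assay and not at a number: the limit of > 100000 nM in this assay, at which 1 of the 4 values shown sits.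

The compounds shown do not tell whether the drop depends on the iodine itself or on where it sits on the ring, a question that 3-chlorophenyl, 3-bromophenyl or plain phenyl on the same oxygen could help to settle. They also leave open what 3-iodophenyl does on the core of compound 1, without the extra methyl, and so whether the two changes act independently of each other.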